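This account rests on a few compounds, and the source may have more. Where it says the series, first, only, none or still open, it means among the compounds named here.

Compound 3 `CC(C)=C(C)C#Cc1ccc(CCC(=O)O)cc1` gives in a functional assay on 1321-N1 cells for agonist activity at Free fatty acid receptor 1 (Homo sapiens), read by calcium flux, with a stated time of 0.4 s (on this read-out higher numbers stand for an effect only at larger amounts of compound and lower numbers for an effect already at smaller amounts), a value of 83.2 nM, the lowest of the two numbers shown here. Compound 1 `O=C(O)CCc1ccc(C#CC2CCCC2)cc1` gives in this assay 490 nM. Compound 2 `C#Cc1ccc(CCC(=O)O)cc1` reaches in this assay only a limit, > 100000 nM. Among the measured compounds shown here, two steps bear on the change to come: a 5.9-fold lower number from compound 1 to compound 3 (0.77 log units; beyond the scatter), and an at least 1200-fold lower number from compound 2 to compound 3 (3.07 log units; beyond the scatter), while an at least 200-fold higher number from compound 1 to compound 2 (2.30 log units; beyond the scatter) shows how much a bare hydrogen on that carbon costs. Compound 4 `O=C(O)CCc1ccc(C#CC2=CCCCC2)cc1` differs from compound 3 by cyclohex-1-en-1-yl in place of 1,2-dimethylprop-1-en-1-yl on a triple-bonded carbon. Since both groups keep a substituted double bond on the triple-bonded carbon, a step of a 1.8-fold higher number from compound 3 to compound 4 (0.26 log units; within the scatter) is expected, within the scatter. Compound 4 is therefore estimated at 150 nM, with a range from 40 nM to 600 nM.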

Compound 4, half-maximal effective concentration: 200 nM
Beside the measured number, compound 4's estimate is 1.3-fold (0.12 log units) below it, within the range that was stated.
By their numbers in this assay, from the lowest: compound 3; then compound 4; then compound 1. At a limit, above all of these: compound 2.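

The double bond on the triple-bonded carbon can sit in a ring, but in this assay the ring is not a neutral swap for the open-chain group, with a 2.4-fold higher number from compound 3 to compound 4 (0.38 log units; beyond the scatter). Cyclohex-1-en-1-yl still improves on cyclopentyl, with a 2.5-fold lower number from compound 1 to compound 4 (0.39 log units; beyond the scatter), although ring size changes there too. The gain over a bare hydrogen, an at least 500-fold lower number from compound 2 to compound 4 (2.69 log units; beyond the scatter), is large, yet it rests on a limit rather than a number: the limit of > 100000 nM in this assay, at which 1 of the 4 values shown sits.

Open, from the compounds shown here alone, is how cyclohexyl, a six-membered ring without the double bond, would compare. So is phenyl on the same carbon.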